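Swapping a Pyridine Attachment Point on a Fused Core

This account rests on a few compounds, and the source may have more. Where it says the series, first, only, none or still open, it means among the compounds named here.

In a functional assay on ovarian cells (Homo sapiens) for antiproliferative activity (a lower number here means a stronger inhibitor of growth, a higher number a weaker inhibitor of growth), compound 2 `Cc1cn2c(/C=N/NC(=N)N)c(-c3cccnc3)nc2s1` gives 15800 nM. Compound 1 `Cc1cn2c(/C=N/NC(=N)N)c(-c3ccncc3)nc2s1` differs from it by pyridin-4-yl in place of pyridin-3-yl on an aromatic carbon and gives 16600 nM, so that change made a 1.1-fold higher number from compound 2 to compound 1 (0.02 log units; within the scatter). Compound 3 `N=C(N)N/N=C/c1c(-c2cccnc2)nc2sc(Cl)cn12` differs from compound 2 by chloro in place of methyl on an aromatic carbon, and compound 3 gives 15500 nM; that change made a 1.0-fold lower number from compound 2 to compound 3 (0.01 log units; within the scatter). Compound 4 `N=C(N)N/N=C/c1c(-c2ccncc2)nc2sc(Cl)cn12` has not yet been measured in this assay. It differs from compound 3 by pyridin-4-yl in place of pyridin-3-yl on an aromatic carbon, the same change, at the same place, as that from compound 2 to compound 1; only the cores differ, in the way just told. Because the earlier step was a 1.1-fold higher number from compound 2 to compound 1 (0.02 log units; within the scatter), compound 4 is expected to show a 1.0-fold higher number from compound 3 to compound 4 (0.01 log units; within the scatter) in this assay. The estimate for compound 4 is 16000 nM, expected to fall between 8000 nM and 32000 nM.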

Compound 4, concentration for 50% growth inhibition: 10200 nM
Beside the measured number, compound 4's estimate is 1.6-fold (0.20 log units) above it; the measured number falls inside the stated range.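

In this assay both a 1.5-fold lower number from compound 3 to compound 4 (0.18 log units; within the scatter) and a 1.6-fold lower number from compound 1 to compound 4 (0.21 log units; within the scatter) lie within the usual scatter, so neither change shows a real effect on growth inhibition here, and nothing shows how a change with a large effect would carry between cores. Pyridin-4-yl in place of pyridin-3-yl reads alike on the two cores: the same change on two cores in this assay, a 1.1-fold higher number (0.02 log units; within the scatter) from compound 2 to compound 1 and a 1.5-fold lower number (0.18 log units; within the scatter) from compound 3 to compound 4, 1.6-fold (0.20 log units) apart, within the scatter of two such steps. Chloro in place of methyl also reads alike with either pyridine: the same change on two cores in this assay, a 1.0-fold lower number (0.01 log units; within the scatter) from compound 2 to compound 3 and a 1.6-fold lower number (0.21 log units; within the scatter) from compound 1 to compound 4, 1.6-fold (0.20 log units) apart, within the scatter of two such steps.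

The compounds shown leave open whether an amine, a carboxylic acid or a longer chain in place of the chloro or methyl would move the number beyond the scatter. They also leave open whether such a step would hold on both cores.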